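Isopropyl to cyclopropylmethyl on the sulfonyl of compound 1

The source may hold more compounds than are shown below. What is called first, only, known or untested is meant among the compounds shown, and "the series" means these compounds.

Going by the values given here, compound 1, with the structure `CC(C)S(=O)(=O)N1C[C@@H]2[C@H](C1)[C@@]2(CNC(=O)c1ccc(Cl)cc1Cl)CC1CC1`, is the weaker of the two compounds measured so far. In an assay on isolated protein for inhibition of sodium- and chloride-dependent glycine transporter 1 (Homo sapiens) (on this read-out higher numbers stand for weaker inhibition and lower numbers for stronger inhibition), compound 1 gives 3400 nM, the higher of the two numbers. Compound 2, with the structure `Cn1cnc(S(=O)(=O)N2C[C@@H]3[C@H](C2)[C@@]3(CNC(=O)c2ccccc2Cl)CC2CC2)c1`, gives in this assay a value of 19 nM; the two compounds differ in more than one place, so the gap between their numbers, which lies beyond the usual scatter, is not attributed to any single change.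

Compound 3, with the structure `O=C(NC[C@]1(CC2CC2)[C@@H]2CN(S(=O)(=O)CC3CC3)C[C@@H]21)c1ccc(Cl)cc1Cl`, follows from compound 1 by one change: cyclopropylmethyl in place of isopropyl on a sulfonyl sulfur. Among the compounds with values here, no measured pair shows this change on its own, so its effect is unknown. The swap exchanges one small saturated carbon group for another, and the amide part of the molecule, which separates compound 1 from compound 2, is left untouched. The step is therefore expected to be modest, with a lean toward a somewhat lower number, and compound 3 is expected to lie at 2000 nM with a range from 700 nM to 6000 nM, corresponding to an estimated step of a 1.7-fold lower number from compound 1 to compound 3 (0.23 log units; within the scatter).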

Compound 3, half-maximal inhibitory concentration: 230 nM
Compound 3: middle estimate off by 8.7-fold (0.94 log units), on the high side; measured number below the stated range.
By their numbers in this assay, from the lowest: compound 2; then compound 3; then compound 1.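

In this assay, the sulfonyl substituent turns out to be a place where a small exchange matters: cyclopropylmethyl in place of isopropyl on a sulfonyl sulfur gives a 15-fold lower number from compound 1 to compound 3 (1.17 log units; beyond the scatter), with the amide part of the molecule left unchanged. Compound 1 and compound 2 differ in more than one place. Compound 1 and compound 3 differ in this one place only, and the step between them lies beyond the usual scatter. The exchange takes 3 heavy atoms out and puts 4 in, adds a three-membered ring and leaves the count of hydrogen-bond donors and acceptors at zero on both sides, and no measurement at hand explains why so modest an exchange goes with so large a step.

The compounds shown do not separate the contribution of the ring from that of the extra carbon, which a straight butyl chain or a plain cyclopropyl on the sulfonyl sulfur would address. As far as these compounds go, it also remains open whether the same exchange gives a step of similar size when the amide part of the molecule is a different one.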